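The compounds below may be only part of what the source reports. "The series", "measured", "known", "first", "only" and "open" are said of these compounds alone.

Compound 1, whose structure is `O=C(Nc1cccc(-n2cc(-c3ccncc3)c(-c3cc(O)cc(Cl)c3)n2)c1)Nc1ccc(Cl)c(C(F)(F)F)c1`, was tested in a functional assay on KM12 cells (Homo sapiens) for inhibition, read by sulforhodamine B assay, with a stated time of 48 h, tested at 0.01 uM (a higher number here means a weaker effect of the compound at the concentration tested, a lower number a stronger effect), where compound 1 gives 91%. Its companion compound 2, with the structure `O=C(Nc1cccc(-n2cc(-c3ccncc3)c(-c3cc(O)cc(Cl)c3)n2)c1)Nc1ccc(Cl)c(Cl)c1`, gives in this assay a value of 102% for compound 2. Among these two numbers compound 1 stands lowest, and the one measured step, a number 11 percentage points higher from compound 1 to compound 2 (beyond the scatter), arises from a chloro in place of a trifluoromethyl on an aromatic carbon.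

The compound now considered is compound 3, with the structure `COc1cc(Cl)cc(-c2nn(-c3cccc(NC(=O)Nc4ccc(Cl)c(C(F)(F)F)c4)c3)cc2-c2ccncc2)c1`. It differs from compound 1 by methyl in place of hydrogen on an oxygen on an aromatic ring. Going by the values given here, the single measured step, from a chloro for a trifluoromethyl, touches a different part of the shared core and does not bear on a change at this oxygen; no measured pair shows what a hydroxy to methoxy exchange does here. With nothing to lean on, the step in this assay from compound 1 to compound 3 is expected to be small, a number 4 percentage points higher from compound 1 to compound 3 (within the scatter), and its direction is uncertain. Compound 3 is therefore estimated to give 95% in this assay, within a range of 72% to 115%.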

Compound 3, a percentage reported as activity, at one concentration (the size of the read-out at that concentration, not a potency): 95%
Compound 3: the middle estimate sits on the measured number at the digits printed, within the range that was stated.
By their numbers in this assay, from the lowest: compounds 1, 3 and 2 (each within the scatter of the next, the first and the last beyond it).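

On the 3-chloro-5-hydroxyphenyl group, the change from hydroxy to methoxy gives in this assay a number 4 percentage points higher from compound 1 to compound 3 (within the scatter), so at this oxygen methyl can take the place of hydrogen with no difference that stands out from the scatter in this read-out. Going by these compounds alone, the earlier pair spoke only of a different place on the shared core, where the exchange of trifluoromethyl for chloro gave a number 11 percentage points higher from compound 1 to compound 2 (beyond the scatter), and this step adds a first reading at the oxygen itself. No measurement offered here gives any explanation for what is seen at this position.

The read-out is the size of the effect at one concentration and not a potency, and with so few compounds it leaves open whether the same step would hold where the compounds act more strongly. Also open, from the compounds shown here alone, is what a longer chain on this oxygen, such as ethoxy, or an amine or a carboxylic acid in place of the hydroxy would do, and whether methoxy behaves the same when chloro stands in place of trifluoromethyl.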